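The compounds below may be only part of what the source reports. "The series", "measured", "known", "first", "only" and "open" are said of these compounds alone.

The step from compound 1 to compound 4 is traced here in an ADME assay on microsomes from liver (Rattus norvegicus) for metabolic stability (on this read-out lower numbers stand for a shorter-lived compound and higher numbers for a longer-lived compound), alone. Compound 1 has the structure `CCn1ncc2c(F)cc(-c3ccc(C(CC)(CC)c4ncn(C)n4)c(=O)[nH]3)cc21`. In this assay compound 1 gives > 3 h, which is a limit of the assay rather than a number. Compound 2, with the structure `CC(C)C(c1noc(=O)[nH]1)c1ccc(-c2ccc3cccc(F)c3c2)[nH]c1=O`, also reaches a limit and gives > 3 h in this assay. Compound 3, with the structure `CC(C)C(Nc1nnc[nH]1)c1ccc(-c2ccc3cccc(F)c3c2)[nH]c1=O`, gives 1.29 h in this assay. Among the measured compounds shown here, the only step between measured compounds that differ in one place is an at least 2.3-fold lower number from compound 2 to compound 3 (0.36 log units; beyond the scatter); it concerns a different ring exchange at a different kind of carbon, so it does not bear directly on the step from compound 1 to compound 4. Compound 4 has the structure `CCn1ncc2c(F)cc(-c3ccc(C(CC)(CC)c4nncn4C)c(=O)[nH]3)cc21`. It differs from compound 1 by 4-methyl-4H-1,2,4-triazol-3-yl in place of 1-methyl-1H-1,2,4-triazol-3-yl on a saturated chain carbon bound to an aromatic carbon and two saturated chain carbons. Two of the three values shown sit at the limit, as noted in the limit of > 3 h in this assay, at which 2 of the 3 values shown sit. For the measured compounds named here, with no measured step of the same kind, the expectation for compound 4 is no step beyond the scatter in this assay, and compound 4 is estimated to give 3 h, within 1.5 h to 6 h, which means an expected step of a number no higher from compound 1 to compound 4 (the limit leaves the size open).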

Compound 4, half-life: > 3 h
Compound 4: a limit, no number (the forecaster's own chance of this, stated with the estimate: 60%); the middle value lies on the limit itself.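

In this assay compound 4 gives > 3 h, which is a limit of the assay and not a number. Among the compounds shown here, compound 1 also stands at a limit, so no step from compound 1 to compound 4 can be read. The compounds shown leave open whether this exchange of triazole groups alters the half-life at all, and in which direction: the limit of > 3 h in this assay, at which 3 of the 4 values shown sit.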